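A few compounds are considered here, and "the series" means these few. Any claim that something is new, unique, unknown or untested is made for them only; others in the source may bear on it.

Measured so far in a functional assay on MCF7 cells (Homo sapiens) for inhibition, read by MTT assay, with stated times of 18 h and 4 h; on this read-out higher numbers stand for weaker inhibition and lower numbers for stronger inhibition

- Compound 1 `CCCCCCCCOP(=O)(O)OCCSC(=S)N1CCCCCC1` gives 78000 nM
- Compound 2 `CCCCCCCCCCOP(=O)(O)OCCSC(=S)N1CCCCC1` gives 7240 nM
- Compound 3 `CCCCCCOP(=O)(O)OCCSC(=S)N1CCCCCC1` gives 55000 nM

Compound 3 belongs to the upper pair of these three numbers, level with compound 1 within the scatter, while compound 2 sits clearly lower than compound 3. The next compound is compound 4 `CCCCCCOP(=O)(O)OCCSC(=S)N1CCCCC1`, which keeps the hexyl chain of compound 3 and changes only the ring: piperidin-1-yl in place of azepan-1-yl on a thiocarbonyl carbon. In words, piperidin-1-yl stands in place of azepan-1-yl on a thiocarbonyl carbon.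

Within the data shown here, only one measured step changes a single place, and it concerns the chain, not the ring: a 1.4-fold lower number from compound 1 to compound 3 (0.15 log units; within the scatter). Among the measured compounds shown here, no measured pair isolates the ring change. Compound 2 also carries the piperidin-1-yl group, but its decyl chain differs too, so its gap to compound 3 cannot be assigned to the ring alone. A modest move toward a lower number is therefore expected in this assay, much smaller than that gap and with real uncertainty. The expected size is a 1.6-fold lower number from compound 3 to compound 4 (0.20 log units; within the scatter) as an estimate. Compound 4 is estimated at 35000 nM, with an expected range from 12000 nM to 90000 nM as the measurement is awaited.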

Compound 4, half-maximal inhibitory concentration: 62000 nM
Compound 4: middle estimate off by 1.8-fold (0.25 log units), on the low side; low and high end bracket the measured number.
By their numbers in this assay, from the lowest: compound 2; then compounds 3, 4 and 1 (each within the scatter of the next).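

In this assay, with the hexyl chain held fixed, placing piperidin-1-yl instead of azepan-1-yl on the thiocarbonyl carbon gives a 1.1-fold higher number from compound 3 to compound 4 (0.05 log units; within the scatter), so this ring swap makes no readable difference between these two compounds. With the piperidin-1-yl ring held fixed instead, the chain can now be read on its own: going from the decyl chain to the hexyl chain gives an 8.6-fold higher number from compound 2 to compound 4 (0.93 log units; beyond the scatter), so the lower number of compound 2 goes with its longer chain and not with its ring. Nothing available explains why the chain change registers here while the ring swap does not.

The chain effect is not yet a smooth trend, since going from the octyl chain to the hexyl chain on the azepan-1-yl ring gives a 1.4-fold lower number from compound 1 to compound 3 (0.15 log units; within the scatter), which leaves open where along the chain the number starts to fall and whether a dodecyl chain would take it lower still. Also open, as far as these compounds go, is what a ring with a second hetero atom, such as morpholin-4-yl, would give at the thiocarbonyl carbon.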